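The source may hold more compounds than are shown below. What is called first, only, known or untested is meant among the compounds shown, and "the series" means these compounds.

Three analogues that share one core were measured in a functional assay on SK-OV-3 cells (Homo sapiens) for inhibition, read by sulforhodamine B assay, with a stated time of 48 h; a higher number here means that more compound is tolerated, a lower number that less compound is tolerated. For compound 1 `Nc1cc(N)c2nc(-c3ccccc3)c(Oc3ccc(Cl)c(Cl)c3)nc2c1` the assay reports only a limit, < 100000 nM. Compound 2 `Nc1cc(N)c2nc(-c3ccccc3)c(NCc3ccc(F)cc3)nc2c1` gives 53700 nM. For compound 3 `Nc1cc(N)c2nc(-c3ccccc3)c(Sc3ccc(Cl)c(Cl)c3)nc2c1` the result is again a limit, < 100000 nM, so compound 3 stands where most of the shown values sit, as the limit of < 100000 nM in this assay, at which 2 of the 3 values shown sit, records. The measured steps a step that the limit leaves unreadable from compound 1 to compound 2, a step that the two limits leave unreadable from compound 1 to compound 3 and a step that the limit leaves unreadable from compound 2 to compound 3 therefore carry no readable size. The unmeasured compound 4 `Nc1cc(N)c2nc(-c3ccccc3)c(Oc3ccc(F)cc3)nc2c1` differs from compound 3 in one place: 4-fluorophenoxy in place of (3,4-dichlorophenyl)sulfanyl on an aromatic carbon. Within the data shown here, none of the measured steps speaks readably to this change, so no direction beyond the scatter can be drawn from them. Compound 4 is expected near 60000 nM, somewhere within 15000 nM to 100000 nM, which would mean an expected step that the limit leaves unreadable from compound 3 to compound 4.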

Compound 4, concentration lethal to 50% of the cells: 83200 nM
For compound 4 the middle estimate is 1.4-fold (0.14 log units) below the measured one; the measured number falls inside the stated range.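

Among these compounds, measured in this assay, 4-fluorophenoxy in place of (4-fluorobenzyl)amino gives the first readable step at this carbon next to the ring nitrogen, a 1.5-fold higher number from compound 2 to compound 4 (0.19 log units; within the scatter), so this change does not separate the two groups. The steps to compound 4 from compound 1 and from compound 3 cannot be read, as each of those two compounds stands only as a limit: the limit of < 100000 nM in this assay, at which 2 of the 4 values shown sit. Still open, as far as these compounds go, is what 3,4-dichlorophenyl in place of 4-fluorophenyl does on the oxygen. Also open, from the compounds shown here alone, is whether a piperazine or a carboxylic acid on this carbon would move the number beyond the scatter.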